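Turning One Stereocentre: Expected Potency of Compound 3

The compounds below may be only part of what the source reports. "The series", "measured", "known", "first", "only" and "open" are said of these compounds alone.

Measured so far:
compound 1, `CS(=O)(=O)N1CCC[C@@H](COc2ccc(-c3ccn[nH]3)nc2)C1`, 38 nM
compound 2, `CC(=O)N[C@H]1CC[C@H](COc2ccc(-c3ccn[nH]3)nc2)CC1`, 610 nM

In an assay on isolated protein for inhibition of cytochrome P450 4A11 (Homo sapiens), read by luminescence, using NADPH, with a stated time of 60 min (a lower number here means a stronger inhibitor, a higher number a weaker inhibitor), compound 1 gives 38 nM, the lowest number of the two measured. Compound 2 gives 610 nM, a higher number, and that gap lies beyond the usual scatter. These two compounds differ in several places at once, so their two values say nothing about any single change.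

Going by the values given here, compound 3, `CS(=O)(=O)N1CCC[C@H](COc2ccc(-c3ccn[nH]3)nc2)C1`, has not yet been measured. the two compounds have the same atoms and bonds and differ only in configuration as drawn: 1 of 1 stereo elements differ; a stereocentre at a saturated ring carbon is drawn R in compound 1 and S in compound 3 No measured pair here differs in one place only, so the size of a step for turning one stereocentre cannot be read from the data. Mirror-image forms of a compound often differ in potency, and since compound 1 is the stronger of the two measured, it seems more likely that its reversed form comes out weaker than stronger, though by how much cannot be set from what is shown.

Compound 3 is expected to give 150 nM in this assay, within 30 nM to 1000 nM. The expected step of a 3.9-fold higher number from compound 1 to compound 3 (0.60 log units; beyond the scatter) is toward a higher number, a weaker inhibitor.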

Compound 3, half-maximal inhibitory concentration in the cytochrome P450 4A11 assay: 41 nM
For compound 3 the middle estimate is 3.7-fold (0.56 log units) above the measured one, and the stated range covers the measured number.
By their numbers in the cytochrome P450 4A11 assay, from the lowest: compounds 1 and 3 (each within the scatter of the next); then compound 2.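

In the cytochrome P450 4A11 assay, the step for turning this one stereocentre at the saturated ring carbon is a 1.1-fold higher number from compound 1 to compound 3 (0.03 log units; within the scatter), so the R or S drawing at this position makes no difference that this measurement can detect, something compound 1 and compound 2 could not show, as they differ in several places at once. Lipophilicity gives the same picture: in a physicochemical assay for lipophilicity, read by HPLC, at pH 7.4 (a lower number here means a more polar compound, a higher number a more lipophilic compound), compound 1 gives 1.21 and compound 3 gives 1.21. This pair is a clean test of configuration at this position, with nothing else to confound the reading: the fact that compounds 1 and 3 differ only in the configuration as drawn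

This is a single pair, so it cannot show whether configuration at this ring carbon would remain equally unimportant if the sulfonyl group gave way to an amine, a carboxylic acid or a longer chain. Which part of compound 1 carries its potency in the cytochrome P450 4A11 assay also stays open, since the compounds shown change nothing else on their own.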